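This account rests on a few compounds, and the source may have more. Where it says the series, first, only, none or still open, it means among the compounds named here.

In a functional assay on K562 cells (Homo sapiens) for antiproliferative activity, with a stated time of 72 h (on this read-out higher numbers stand for weaker inhibition and lower numbers for stronger inhibition), compound 1 `OC[C@H]1O[C@@H](n2cnc3c(NCc4ccc(Cl)cc4)ncnc32)[C@H](O)[C@@H]1O`, with 4-chlorophenyl on a saturated chain carbon bound to a nitrogen on an aromatic ring, gives 218000 nM. Compound 2 `OC[C@H]1O[C@@H](n2cnc3c(NCc4ccccc4Br)ncnc32)[C@H](O)[C@@H]1O`, with 2-bromophenyl at that place on the shared core, gives 10000 nM, the lower of the two actual numbers. Compound 3 `Cc1ccc(CNc2ncnc3c2ncn3[C@@H]2O[C@H](CO)[C@@H](O)[C@H]2O)cc1`, with 4-methylphenyl there, is reported only as a limit, > 166000 nM.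

Compound 4 `COc1cccc(CNc2ncnc3c2ncn3[C@@H]2O[C@H](CO)[C@@H](O)[C@H]2O)c1` has not yet been measured. Its difference from compound 2 is 3-methoxyphenyl in place of 2-bromophenyl on a saturated chain carbon bound to a nitrogen on an aromatic ring, which also reads as 2-bromobenzyl to 3-methoxybenzyl. Within the data shown here, no measured compound carries 3-methoxyphenyl, so the evidence is indirect. Two large steps bear on the change. Gaining 2-bromophenyl gave a 22-fold lower number from compound 1 to compound 2 (1.34 log units; beyond the scatter), and leaving it gave an at least 16-fold higher number from compound 2 to compound 3 (1.22 log units; beyond the scatter). Both steps place compound 2 well apart from the other two compounds, so a move away from 2-bromophenyl is expected to raise the number again, though the size of that rise is uncertain. The expected change in this assay is a 6.0-fold higher number from compound 2 to compound 4 (0.78 log units; beyond the scatter), a large step toward weaker inhibition. For compound 4 the estimated value is 60000 nM, with an expected range from 15000 nM to 220000 nM.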

Compound 4, half-maximal inhibitory concentration: > 166000 nM
Compound 4 ended at the assay's limit (the forecaster's own chance of this, stated with the estimate: 25%); middle value at least 2.7-fold (0.44 log units) from the limit.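

Compound 4 gives > 166000 nM in this assay, and this value is a limit. With 3-methoxyphenyl in place of 2-bromophenyl on a saturated chain carbon bound to a nitrogen on an aromatic ring, the result is an at least 16-fold higher number from compound 2 to compound 4 (1.22 log units; beyond the scatter), so a group with an oxygen and a hydrogen-bond acceptor at this place does not bring back the low number of compound 2. Compound 2 now stands apart from three compounds with different groups at this place, 4-chlorophenyl, 4-methylphenyl and 3-methoxyphenyl, and the true size of the step from 2-bromophenyl to 3-methoxyphenyl stays unknown because the reading of compound 4 stops at a limit: the limit of > 166000 nM in this assay, at which 2 of the 4 values shown sit.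

The steps from compound 1 to compound 4 and from compound 3 to compound 4 cannot be read, so 3-methoxyphenyl cannot be ranked against 4-chlorophenyl or 4-methylphenyl. On these data alone, it also remains open whether the lower number of compound 2 follows the bromine itself or its place on the ring, a question that 2-chlorophenyl or 4-bromophenyl at this position would address.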